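The source may report more compounds than this note shows. Statements on the series, on what has been measured and on what is new or still open speak of the compounds shown alone.

Compound 1, `CC1=CC(=O)/C(=C(/C)Nc2ccc3c(Cl)n(Cc4ccc(C)cc4)nc3c2)C(=O)O1`, was tested in an ADME assay on RAW264.7 cells (Mus musculus) for cytotoxicity, read by resazurin assay, with a stated time of 48 h; a higher number here means that more compound is tolerated, a lower number that less compound is tolerated. In this assay compound 1 reaches only the limit of > 100000 nM, not a number. Compound 2, `CC1=CC(=O)/C(=C(/C)Nc2ccc3c(cnn3C)c2)C(=O)O1`, likewise gives only the limit of > 100000 nM in this assay. Both values therefore sit at the limit of > 100000 nM in this assay, at which 2 of the 2 values shown sit, so compound 2 stands at the edge of the measured range rather than at a point within it. Compound 3, `CCn1ncc2cc(N/C(C)=C3\C(=O)C=C(C)OC3=O)ccc21`, carries methyl in place of hydrogen on a saturated chain carbon bound to an aromatic nitrogen. Among the measured compounds shown here, with no measured step of this kind to draw on, the step from compound 2 to compound 3 is expected to be a number no higher from compound 2 to compound 3 (the limit leaves the size open), nothing beyond the usual scatter. Compound 3 is accordingly estimated at 100000 nM, within 50000 nM to 200000 nM.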

Compound 3, half-maximal cytotoxic concentration: > 100000 nM
Compound 3: a limit, no number (the forecaster's own chance of this, stated with the estimate: 80%); the middle value lies on the limit itself.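

In this assay compound 3 gives > 100000 nM, a limit and not a number. No step can be read between compound 2 and compound 3, as both values are limits. The compounds shown leave open the concentration at which any of them becomes cytotoxic: the limit of > 100000 nM in this assay, at which 3 of the 3 values shown sit.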